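The compounds below may be only part of what the source reports. "The series", "measured", "known", "first", "only" and "open" are said of these compounds alone.

Measured compounds:
compound 1 `O=C(NC(c1ccc2ccccc2c1)C1CCNCC1)c1ccc2cnccc2c1` with 400 nM
compound 2 `N#Cc1cc(C(NC(=O)c2ccc3cnccc3c2)C2CCNCC2)ccc1Cl` with 80 nM

In an assay on isolated protein for inhibition of RAC-alpha serine/threonine-protein kinase (Homo sapiens) (a lower number here means a stronger inhibitor, a higher number a weaker inhibitor), compound 1 gives 400 nM, the highest of the two numbers shown; its nearest neighbour is compound 2, and the step of a 5.0-fold lower number from compound 1 to compound 2 (0.70 log units; beyond the scatter) lies beyond the scatter. Compound 3 `O=C(NC(c1ccc(Cl)c(F)c1)C1CCNCC1)c1ccc2cnccc2c1` has not yet been measured in this assay. It differs from compound 1 in a single place: 4-chloro-3-fluorophenyl in place of naphthalen-2-yl on a saturated chain carbon bound to an amide-type nitrogen and a saturated ring carbon. For the measured compounds named here, the one measured step that bears on this change is the move from compound 1 to compound 2, where a 4-chloro-3-cyanophenyl took the place of the naphthalen-2-yl on the same saturated chain carbon and gave a 5.0-fold lower number from compound 1 to compound 2 (0.70 log units; beyond the scatter), a modest gain. Compound 3 carries a 4-chloro-3-fluorophenyl on that carbon instead, so the same kind of exchange is made, though with a different group on the ring. Because the earlier step of a 5.0-fold lower number from compound 1 to compound 2 (0.70 log units; beyond the scatter) was modest and beyond the scatter, a lower number than compound 1 is expected for compound 3 as well, with the step of a 2.9-fold lower number from compound 1 to compound 3 (0.46 log units; beyond the scatter) estimated to be somewhat smaller. Compound 3 is therefore expected to give about 140 nM in this assay, within a range from 50 nM to 400 nM.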

Compound 3, half-maximal inhibitory concentration: 40 nM
For compound 3 the middle estimate is 3.5-fold (0.54 log units) above the measured one; the whole stated range lies above it.
By their numbers in this assay, from the lowest: compounds 3 and 2 (each within the scatter of the next); then compound 1.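

In this assay, 4-chloro-3-fluorophenyl in place of naphthalen-2-yl on the saturated chain carbon gives a 10-fold lower number from compound 1 to compound 3 (1.00 log units; beyond the scatter) and so shows that the gain at this place is not confined to the 4-chloro-3-cyanophenyl of compound 2. Fluoro in place of cyano on an aromatic carbon gives a 2.0-fold lower number from compound 2 to compound 3 (0.30 log units; within the scatter) and leaves compound 2 and compound 3 indistinguishable in this assay, so among the compounds shown the nitrile is not needed for the step away from compound 1, and either single-ring group serves equally well here. No independent evidence is available to explain these differences.

What the compounds shown leave open is how much of the gain rests on the chloro group, as a plain phenyl or a 3-fluorophenyl at the same carbon would be needed to separate its share from that of the other group on the ring. As far as these compounds go, it also remains open whether a methoxy, a trifluoromethyl or an amine on this ring would match the fluoro and the nitrile, and whether the same exchange holds on a different core.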